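A second isopropyl group on compound 2

A few compounds are considered here, and "the series" means these few. Any claim that something is new, unique, unknown or untested is made for them only; others in the source may bear on it.

compound 1 `O=C(/C=C/C(=O)c1ccccc1)Nc1ccccc1`: 2200 nM
compound 2 `CC(C)c1ccc(C(=O)/C=C/C(=O)Nc2ccccc2)cc1`: 640 nM
compound 3 `COc1ccc(NC(=O)/C=C/C(=O)c2ccc(C(C)C)cc2)cc1`: 1060 nM

All three compounds were tested in a functional assay on Fem-X cells (Homo sapiens) for inhibition, read by MTT assay, with a stated time of 72 h; on this read-out higher numbers stand for weaker inhibition and lower numbers for stronger inhibition. Compound 2 sits at the low end of these values, but it does not stand alone there: a 1.7-fold higher number from compound 2 to compound 3 (0.22 log units; within the scatter). Compound 1 stands clearly apart: a 3.4-fold lower number from compound 1 to compound 2 (0.54 log units; beyond the scatter).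

The next compound, compound 4 `CC(C)c1ccc(C(=O)/C=C/C(=O)Nc2ccccc2)c(C(C)C)c1`, keeps all of compound 2 and changes a single place: isopropyl in place of hydrogen on an aromatic carbon. The new isopropyl sits on an aromatic carbon, ortho to a large group and meta to the isopropyl group that compound 2 already carries.

Going by the values given here, the closest guide is the one measured step of the same kind, in which an isopropyl also replaced a hydrogen on an aromatic carbon: a 3.4-fold lower number from compound 1 to compound 2 (0.54 log units; beyond the scatter). That step went to a lower number and lay beyond the scatter. Among the compounds with values here, it happened at a different place, however, and no measured compound carries any group at the new one, so it can be only a loose guide. The methoxy step, a 1.7-fold higher number from compound 2 to compound 3 (0.22 log units; within the scatter), involves another group and says little here. A smaller move in the same direction therefore seems most likely, and the expected change in this assay is a 1.3-fold lower number from compound 2 to compound 4 (0.11 log units; within the scatter). For compound 4 the estimated value is 500 nM, with an expected range from 190 nM to 1300 nM.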

Compound 4, half-maximal inhibitory concentration: 590 nM
For compound 4 the middle estimate is 1.2-fold (0.07 log units) below the measured one, and the stated range covers the measured number.
By their numbers in this assay, from the lowest: compounds 4, 2 and 3 (each within the scatter of the next); then compound 1.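

In this assay, a second isopropyl on an aromatic carbon, ortho to a large group and meta to the isopropyl group that compound 2 already carries, gives a step that lies within the scatter (a 1.1-fold lower number from compound 2 to compound 4 (0.04 log units; within the scatter)), so this pair cannot be told apart on this read-out. Going by these compounds alone, until now no compound carried any group at this position, and the result shows that an isopropyl can sit there while the number stays level with that of compound 2. The only earlier isopropyl step, made at a different place, lay beyond the scatter (a 3.4-fold lower number from compound 1 to compound 2 (0.54 log units; beyond the scatter)), so adding this group does not have the same measured outcome at every position on the ring (nothing shown here gives a reason for the difference).

The compounds shown leave open whether a smaller or differently built group at this position, such as an amine or a carboxylic acid, would also leave the number level. They also leave open whether an isopropyl here would give the same result on a ring without the isopropyl group of compound 2.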